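Compound 3: a new group on a carbonyl carbon

This account rests on a few compounds, and the source may have more. Where it says the series, first, only, none or still open, it means among the compounds named here.

Compound 1 `Cc1ccsc1C(=CCCN(C)C(CCO)C(=O)N1CCOCC1)c1sccc1C` has one number to go on. In a physicochemical assay for lipophilicity, read by HPLC (on this read-out lower numbers stand for lower lipophilicity and higher numbers for higher lipophilicity), compound 1 gives 4.75, and a further entry for it offers no single number. Going by the values given here, the only other measured compound, compound 2 `Cc1ccsc1C(=CCCN(C)C(CC(C)O)C(=O)NCc1ccc(Cl)cc1)c1sccc1C`, stands higher at 5.99; 6.77 (2 entries). Its two readings, (the several entries of compound 2 in this assay, 5.99; 6.77 (2 entries)), lie further apart than the usual scatter, so its position is itself uncertain. Among the compounds with values here, no measured pair differs in just one place, so no step can be read directly from the data.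

Compound 3 `Cc1ccc(CNC(=O)C(CCO)N(C)CCC=C(c2sccc2C)c2sccc2C)cc1` keeps the core of compound 1 and changes one place, with (4-methylbenzyl)amino in place of morpholin-4-yl on a carbonyl carbon. A six-membered non-aromatic ring with 2 hetero atoms leaves, and a six-membered aromatic ring of carbon only enters.

In this assay a clear rise is expected, a number 1.15 log units higher from compound 1 to compound 3 (beyond the scatter), beyond the scatter. Within the data shown here, the only guide to the upper region of this scale is compound 2 at 5.99; 6.77 (2 entries). For compound 3 the estimated value is 5.9, with an expected range of 5.3 to 6.6.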

Compound 3, partition coefficient: 6.2
Beside the measured number, compound 3's estimate is 0.30 log units below it, and the stated range covers the measured number.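

Going by these compounds alone, this is the first step that can be read directly. In this assay, replacing morpholin-4-yl with (4-methylbenzyl)amino on this carbonyl carbon gives a number 1.45 log units higher from compound 1 to compound 3 (beyond the scatter), so this position can carry a large change in the read-out. The swap alters several features at once: a six-membered non-aromatic ring with hetero atoms leaves, while a six-membered aromatic ring of carbon and an amide hydrogen enter, so one step cannot assign the rise to any one of them. Compound 2 differs from compound 3 in more than one place and gives no clean comparison, and its own position is also uncertain: the several entries of compound 2 in this assay, 5.99; 6.77 (2 entries)

The compounds shown leave open how the step divides among the aromatic ring, its methyl group and the amide hydrogen. A plain benzylamino group or a piperidin-1-yl group on the same carbonyl carbon, each set against the core of compound 1, would begin to separate these contributions.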